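Series notes: the step from compound 3 to compound 4

The source may report more compounds than this note shows. Statements on the series, on what has been measured and on what is new or still open speak of the compounds shown alone.

Measured compounds:
compound 1, `CN(C)c1ccc(C(=O)N[C@H](CCCCCC(=O)NO)C(=O)NCc2ccccc2)cc1`, 1000 nM
compound 2, `CN(C)c1ccc(C(=O)NC(CCCCCC(=O)NO)C(=O)NCc2ccccc2)cc1`, 870 nM
compound 3, `O=C(CCCCC[C@H](NC(=O)c1ccc(Br)cc1)C(=O)NCc1ccccc1)NO`, 5860 nM

All three were tested in a functional assay on NFF cells (Homo sapiens) for antiproliferative activity; a lower number here means a stronger inhibitor, a higher number a weaker inhibitor. Compound 3 stands at the highest number of the three, well beyond the scatter from compound 1 and from compound 2; compound 3 and compound 1 differ in more than one place, so their values are noted only side by side. Within the data shown here, the one single-point step in the set is a 1.1-fold lower number from compound 1 to compound 2 (0.06 log units; within the scatter), which is within the scatter and concerns only (the fact that one of compounds 1 and 2 is drawn with a defined configuration and the other without, at the place where they differ); it says nothing about a change on the aromatic ring.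

Compound 4, `O=C(CCCCC[C@H](NC(=O)c1ccc(C(F)(F)F)cc1)C(=O)NCc1ccccc1)NO`, is not yet measured. It differs from compound 3 by trifluoromethyl in place of bromo on an aromatic carbon. Among the measured compounds shown here, no measured step exchanges one substituent for another on that ring, so there is no precedent for the size or direction of this change. The expectation is therefore that compound 4 stays close to compound 3, with a step of a 1.1-fold lower number from compound 3 to compound 4 (0.03 log units; within the scatter), not beyond the scatter. Compound 4 is estimated at 5500 nM, within a range from 2200 nM to 14000 nM.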

Compound 4, half-maximal inhibitory concentration: 1610 nM
Estimate against measurement, compound 4: 3.4-fold (0.53 log units) above; measured number below the stated range.
By their numbers in this assay, from the lowest: compounds 2, 1 and 4 (each within the scatter of the next); then compound 3.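

In this assay, replacing bromo with trifluoromethyl on the aromatic carbon para to a large group gives a 3.6-fold lower number from compound 3 to compound 4 (0.56 log units; beyond the scatter). Among these compounds, this is the first single-point step to change a substituent on the aromatic ring, and it shows that activity in this assay responds to the group at this position; the only earlier step, a 1.1-fold lower number from compound 1 to compound 2 (0.06 log units; within the scatter), concerned a drawn configuration and not the ring, while compounds 3 and 4 share the same drawn configuration and differ only in this substituent. Nothing recorded for the series bears on why this exchange moves the number, so the step stands as an observation without an explanation.

A single exchange gives a size and direction for this pair only, and it does not separate the effect of trifluoromethyl from that of bromo on any property, nor show whether the step would hold on a different core. Going by these compounds, how a nitrile, a methoxy group, an amine or a carboxylic acid at the same aromatic carbon would compare with compounds 3 and 4 remains open.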